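The compounds below may be only part of what the source reports. "The series", "measured", "known", "first", "only" and "open" are said of these compounds alone.

Measured in a functional assay on EC9706 cells (Homo sapiens) for antiproliferative activity, read by MTT assay, with a stated time of 72 h; a lower number here means a stronger inhibitor, a higher number a weaker inhibitor:
- Compound 1 `C/C(=N\NC(=O)c1cccc(S(=O)(=O)N2CCOCC2)c1)c1cccc(N)c1O`: 3520 nM
- Compound 2 `O=C(N/N=C/c1ccccc1O)c1cccc(S(=O)(=O)N2CCOCC2)c1`: 19600 nM
- Compound 3 `CCN(CC)c1ccc(/C=N/NC(=O)c2cccc(S(=O)(=O)N3CCOCC3)c2)c(O)c1`: 920 nM

Compound 2 has the highest number of the three, and the values of compound 1 and compound 3 both lie beyond the scatter from it. That leaves compound 2 as the weakest inhibitor measured so far in this assay.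

Compound 4 `O=C(N/N=C/c1cc(Cl)ccc1O)c1cccc(S(=O)(=O)N2CCOCC2)c1` differs from compound 2 in one place: chloro in place of hydrogen on an aromatic carbon. The new chloro group is para to a hydroxy group, turning 2-hydroxyphenyl into 5-chloro-2-hydroxyphenyl.

Within the data shown here, only one measured step bears on this change, and only loosely. Diethylamino in place of hydrogen on an aromatic carbon gave a 21-fold lower number from compound 2 to compound 3 (1.33 log units; beyond the scatter), which is a large step. It shows that one added group can move the number of compound 2 a long way downward. However, chloro is a different group, and no measured compound carries it, so that size cannot simply be carried over. A smaller step in the same direction is therefore expected, though one that may not clear the scatter.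

The estimated change is a 2.5-fold lower number from compound 2 to compound 4 (0.39 log units; beyond the scatter). Compound 4 is expected at 8000 nM with an estimated range from 2500 nM to 22000 nM.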

Compound 4, half-maximal inhibitory concentration: 2150 nM
The estimate for compound 4 lay 3.7-fold (0.57 log units) above the measured number; measured number below the stated range.
By their numbers in this assay, from the lowest: compound 3; then compounds 4 and 1 (each within the scatter of the next); then compound 2.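

In this assay chloro in place of hydrogen, para to a hydroxy group, gives a 9.1-fold lower number from compound 2 to compound 4 (0.96 log units; beyond the scatter) and so turns 2-hydroxyphenyl into 5-chloro-2-hydroxyphenyl with a clear gain over compound 2. Among these compounds, until now the only single change measured from compound 2 was the diethylamino group, with a 21-fold lower number from compound 2 to compound 3 (1.33 log units; beyond the scatter) as its step, so it could not be told whether a lower number needed a group of that kind; the chloro step shows that one added heavy atom, with no ring and no hydrogen-bond donors or acceptors, also moves the number beyond the scatter. Nothing available here explains why this change has the size it has.

The compounds shown leave open whether fluoro, bromo, methyl or methoxy at this same place, para to the hydroxy group, would give a step of similar size. They also leave open whether chloro elsewhere on this ring would do the same, and whether chloro and diethylamino together in one compound would lower the number further.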